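A few compounds are considered here, and "the series" means these few. Any claim that something is new, unique, unknown or untested is made for them only; others in the source may bear on it.

Measured compounds in the series:
compound 1, `Nc1nc2ccc(OC(F)(F)C(F)F)cc2s1`, value 8.5 mg/kg
compound 2, `COC(=O)Cn1c(=N)sc2cc(OC(F)(F)F)ccc21`, value > 10 mg/kg

In a functional assay on the whole organism with Rattus norvegicus as the target (a higher number here means that more compound is needed for the effect, a lower number that less compound is needed), compound 1 gives 8.5 mg/kg. For compound 2 this assay yields only a limit, > 10 mg/kg, so no number is known for it; it sits at the limit of > 10 mg/kg in this assay, at which 1 of the 2 values shown sits. Among the measured compounds shown here, compound 1 and compound 2 differ at more than one place, so their values can only be set side by side, and with one of them a limit no size of step between them can be read.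

Compound 3, `CNCCn1c(=N)sc2cc(OC(F)(F)F)ccc21`, is not yet measured. It differs from compound 2 in one place: (methylamino)methyl in place of methoxycarbonyl on a saturated chain carbon bound to an aromatic nitrogen.

Since compound 2 gives only a limit, the step to compound 3 cannot be anchored to a measured number. The expectation is that compound 3 will return a measurable dose, which would mean a step from compound 2 to compound 3 of an at least 1.2-fold lower number from compound 2 to compound 3 (0.09 log units; that floor lies within the scatter), though a second limit remains possible. The estimate for compound 3 in this assay is 8 mg/kg, expected to fall between 3 mg/kg and 20 mg/kg.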

Compound 3, dose for half-maximal effect: > 10 mg/kg
Compound 3 gave a limit, no number (the forecaster's own chance of this, stated with the estimate: 40%); middle value at least 1.2-fold (0.09 log units) away from the limit.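

In this assay compound 3 gives > 10 mg/kg, a limit and not a number. Compound 2 also stands at a limit, so no step between compound 2 and compound 3 can be read: the limit of > 10 mg/kg in this assay, at which 2 of the 3 values shown sit.

From the compounds shown here alone, whether (methylamino)methyl in place of methoxycarbonyl changes the required dose at all remains open.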